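Chloro analogue of the arylamide series: expected whole-animal toxicity

The compounds below may be only part of what the source reports. "The series", "measured", "known", "first", "only" and "open" are said of these compounds alone.

Three amides share one core. Compound 3 `C/C(C(=O)NC1CC1)=C(/C)c1ccccc1` gives 150 mg/kg in a toxicity assay on the whole organism (strain Icem-CET (SPF Caw)) for cytotoxicity, with Mus musculus as the target; a higher number here means that more compound is needed for the effect, a lower number that less compound is needed. Compound 1 `C/C(C(=O)NC1CC1)=C(/C)c1ccc(Br)cc1` gives 130 mg/kg and compound 2 `C/C(C(=O)NC1CC1)=C(/C)c1ccc(F)cc1` gives 70 mg/kg. Compound 3 is separated from compound 2 but not from compound 1: a 2.1-fold higher number from compound 2 to compound 3 (0.33 log units; beyond the scatter), whereas a 1.2-fold higher number from compound 1 to compound 3 (0.06 log units; within the scatter). Compound 4 `C/C(C(=O)NC1CC1)=C(/C)c1ccc(Cl)cc1` carries chloro in place of hydrogen on an aromatic carbon, para to a large group. The two halogen-removal steps just cited bear on this change; one is within the scatter and the other is modest. A third halogen is therefore expected to give a lower number than compound 3, most likely within the scatter, a 1.4-fold lower number from compound 3 to compound 4 (0.13 log units; within the scatter). Compound 4 is estimated at 110 mg/kg, with a range from 60 mg/kg to 200 mg/kg.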

Compound 4, dose for half-maximal effect: 150 mg/kg
For compound 4 the middle estimate is 1.4-fold (0.13 log units) below the measured one; measured number inside the range.
By their numbers in this assay, from the lowest: compounds 2, 1, 3 and 4 (each within the scatter of the next, the first and the last beyond it).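

In this assay, chloro para to a large group does not separate from hydrogen, with no change at the digits printed from compound 3 to compound 4 (within the scatter), or from bromo, with a 1.2-fold higher number from compound 1 to compound 4 (0.06 log units; within the scatter). Fluoro does separate from chloro, with a 2.1-fold higher number from compound 2 to compound 4 (0.33 log units; beyond the scatter), yet it stays within the scatter of bromo, so a halogen at this position does not by itself give a lower number. No supporting evidence bears on this result. As far as these compounds go, whether a methoxy group or an amine at this position would give a number separated from that of compound 3 stays open.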